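The compounds below may be only part of what the source reports. "The series", "measured", "known", "first", "only" and "open" are said of these compounds alone.

Compound 1 `COc1ccc(N(C)c2nc(C)nc3ccccc23)cc1C(=O)OCC[Se]C#N` gives 353 nM
Compound 2 `COc1ccc(N(C)c2nc(C)nc3ccccc23)cc1` gives 3 nM
Compound 3 `COc1ccc(N(C)c2nc(C)nc3ccccc23)cc1[Se]C#N` gives 49 nM

In a functional assay on A549 cells (Homo sapiens) for inhibition, read by MTT assay, with a stated time of 48 h (on this read-out lower numbers stand for stronger inhibition and higher numbers for weaker inhibition), compound 1 has the highest number of the three. Compound 4 `COc1ccc(N(C)c2nc(C)nc3ccccc23)cc1C(=O)OCCCCC[Se]C#N` keeps the core of compound 1 and carries a longer chain, the change being a group of 6 heavy atoms (4 carbon, 1 nitrogen, 1 selenium; no ring) in place of a group of 3 heavy atoms (1 carbon, 1 nitrogen, 1 selenium; no ring), on a saturated chain carbon, two bonds along the chain from an oxygen next to a carbonyl group in that chain. Replacing the whole side group gave a 120-fold lower number from compound 1 to compound 2 (2.07 log units; beyond the scatter) and keeping only its selenium-bearing end gave a 7.2-fold lower number from compound 1 to compound 3 (0.86 log units; beyond the scatter) so this side group clearly matters. Neither step alters chain length alone, so neither sets a size or direction for this change. The expected step, a 1.2-fold lower number from compound 1 to compound 4 (0.07 log units; within the scatter) as estimated, is small and probably within the scatter. Compound 4 is expected at 300 nM with an estimated range from 100 nM to 900 nM in this read-out.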

Compound 4, half-maximal inhibitory concentration: 592 nM
Compound 4: the middle estimate sits 2.0-fold (0.30 log units) below what was measured; measured number inside the range.
By their numbers in this assay, from the lowest: compound 2; then compound 3; then compounds 1 and 4 (each within the scatter of the next).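

In this assay, within the data shown here, this is the first change that alters chain length alone, with the selenium-bearing end kept, and it gives a 1.7-fold higher number from compound 1 to compound 4 (0.22 log units; within the scatter). At this saturated chain carbon, then, the larger group of 6 heavy atoms reads the same as the group of 3 within the scatter, unlike the large steps seen when the side group was cut back or removed. Nothing measured here accounts for this result.

Still open, as far as these compounds go, is how a longer chain would read in this assay. The same goes for a chain ending in an amine or a carboxylic acid instead of the selenium-bearing end.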